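Shifting a para substituent on an anilino-substituted bicyclic core

The source may hold more compounds than are shown below. What is called first, only, known or untested is meant among the compounds shown, and "the series" means these compounds.

Three compounds have been measured in a functional assay on the whole organism for inhibition, with Nicotiana tabacum as the target; on this read-out lower numbers stand for stronger inhibition and higher numbers for weaker inhibition:
Compound 1, `Cc1nc(Nc2ccccc2)c2cc[nH]c2n1`: compound 1 gives 550000000 nM.
Compound 2, `Cc1ccc(Nc2[nH]c(C)nc3nccc2-3)cc1`: compound 2 gives 759000000 nM.
Compound 3, `CCc1ccc(Nc2[nH]c(C)nc3nccc2-3)cc1`: compound 3 gives 214000000 nM.

Compound 3 stands lowest of the three in this assay. Within the data shown here, its nearest neighbour is compound 1, and its furthest is compound 2; the only step along one change is a 3.5-fold lower number from compound 2 to compound 3 (0.55 log units; beyond the scatter).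

Compound 4, `COc1ccc(Nc2[nH]c(C)nc3nccc2-3)cc1`, has not yet been measured. It differs from compound 3 by methoxy in place of ethyl on an aromatic carbon. Among the measured compounds shown here, no measured step bears directly on swapping ethyl for methoxy; the single step on this ring, from compound 2 to compound 3, only shows that a small change at this place moved the number by a modest amount. Compound 4 is therefore expected to remain in the range spanned by compounds 2 and 3, with a step of a 1.6-fold higher number from compound 3 to compound 4 (0.21 log units; within the scatter) treated as a cautious guess rather than a prediction. The estimate for compound 4 in this assay is 350000000 nM, with a range from 120000000 nM to 1000000000 nM.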

Compound 4, half-maximal inhibitory concentration: 661000000 nM
For compound 4 the middle estimate is 1.9-fold (0.28 log units) below the measured one; measured number inside the range.
By their numbers in this assay, from the lowest: compound 3; then compounds 1, 4 and 2 (each within the scatter of the next).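

In this assay, swapping ethyl for methoxy on the aromatic carbon reverses most of what ethyl had gained (a 3.1-fold higher number from compound 3 to compound 4 (0.49 log units; beyond the scatter)), so the lower number of compound 3 is not shared by every group of 2 heavy atoms at this place. Methoxy and methyl are not told apart here (a 1.1-fold lower number from compound 2 to compound 4 (0.06 log units; within the scatter)), so of the three groups on this ring only ethyl stands apart, although methoxy alone carries an oxygen and a hydrogen-bond acceptor. Nothing available explains why the numbers fall this way.

On these data alone, it remains open whether a longer chain such as propyl, a halogen such as chlorine or an amine at this place would side with ethyl or with methoxy. As far as these compounds go, whether the gap between ethyl and methoxy holds on any other core also remains open.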